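Indanylamine and Tryptamine Piperidines at the Serotonin 1D Receptor

This account rests on a few compounds, and the source may have more. Where it says the series, first, only, none or still open, it means among the compounds named here.

compound 1, `c1ccc2c(c1)CCC2NC1CCN(CCCc2c[nH]c3ccc(-n4cnnc4)cc23)CC1`: 68%
compound 2, `CC(=O)Nc1ccc([C@H](C)NCC2CCN(CCCc3c[nH]c4ccc(-n5cnnc5)cc34)CC2)cc1`: 99%
compound 3, `CC(C)=CCN(C)C1CCN(CCCc2c[nH]c3ccc(-n4cnnc4)cc23)CC1`: 115%

In a functional assay on CHO cells for activation of 5-hydroxytryptamine receptor 1D (Homo sapiens), read by GTPgammaS binding (on this read-out lower numbers stand for smaller maximal responses and higher numbers for larger maximal responses), compound 3 gives 115%, the highest of the three values. Compound 2 gives 99%, and compound 1 gives 68%, both beyond the scatter below compound 3. Compound 4 `c1ccc2c(c1)CCC2NCC1CCN(CCCc2c[nH]c3ccc(-n4cnnc4)cc23)CC1` differs from compound 3 in one place: ((2,3-dihydro-1H-inden-1-yl)amino)methyl in place of methyl(3-methylbut-2-en-1-yl)amino on a saturated ring carbon. The step that bears on it is a number 47 percentage points higher from compound 1 to compound 3 (beyond the scatter), in which the (2,3-dihydro-1H-inden-1-yl)amino group left and a large gain followed. Compound 4 brings that group back, but as ((2,3-dihydro-1H-inden-1-yl)amino)methyl, an arrangement resembling that of compound 2 with 99%. A decrease is therefore expected, smaller than a full reversal: a number 30 percentage points lower from compound 3 to compound 4 (beyond the scatter). Compound 4 is estimated at 85%, within 62% to 105%.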

Compound 4, largest response reached (reported as efficacy), in percent of the reference or control that the assay uses: 78%
The estimate for compound 4 lay 7 percentage points above the measured number; the range from low to high includes it.
By their numbers in this assay, from the lowest: compounds 1 and 4 (each within the scatter of the next); then compound 2; then compound 3.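

In this assay, the indanyl-bearing ((2,3-dihydro-1H-inden-1-yl)amino)methyl group on the saturated ring carbon gives a number 37 percentage points lower from compound 3 to compound 4 (beyond the scatter) in place of methyl(3-methylbut-2-en-1-yl)amino, so this position tolerates the exchange poorly. Adding the methyl link to the (2,3-dihydro-1H-inden-1-yl)amino group gives only a number 10 percentage points higher from compound 1 to compound 4 (within the scatter) and so does not separate the two. With that link kept, 2,3-dihydro-1H-inden-1-yl in place of 1-(4-acetamidophenyl)ethyl on the amine nitrogen gives a number 21 percentage points lower from compound 2 to compound 4 (beyond the scatter) and shows that the nitrogen substituent also matters. No measurement shown explains these steps. Going by these compounds, whether a cyclohexyl group on that amine nitrogen would keep the larger response remains open.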